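This account rests on a few compounds, and the source may have more. Where it says the series, first, only, none or still open, it means among the compounds named here.

Going by the values given here, compound 2 `CC(C)c1noc(N2CCC(Oc3cc(N4CCc5cc(N6CCC(O)CC6=O)ccc54)ncn3)CC2)n1` stands as the higher of the two numbers so far in an ADME assay on microsomes from liver (Homo sapiens) for metabolic stability, read by LC-MS, using NADPH, with a stated time of 30 min, tested at 1 uM (a lower number here means slower removal, a higher number faster removal of the compound), where compound 2 gives 4 mL.min-1.g-1. Among the compounds with values here, its only neighbour is compound 1 `CC(C)c1noc(N2CCC(Oc3cc(N4CCc5cc(N6CC(O)CCC6=O)ccc54)ncn3)CC2)n1`, which in this assay gives 1 mL.min-1.g-1; the single measured step is a 4.0-fold higher number from compound 1 to compound 2 (0.60 log units; beyond the scatter). Compound 3 `CC(C)c1noc(N2CCC(Oc3cc(N4CCc5cc(N6CCCS6(=O)=O)ccc54)ncn3)CC2)n1` is not yet measured. The change from compound 2 is a group of 7 heavy atoms (3 carbon, 1 nitrogen, 2 oxygen, 1 sulfur; one five-membered non-aromatic ring with 2 hetero atoms) in place of a group of 8 heavy atoms (5 carbon, 1 nitrogen, 2 oxygen; one six-membered non-aromatic ring with 1 hetero atom), on an aromatic carbon. Within the data shown here, the one measured step sits on the same aromatic carbon but only moves a hydroxyl within a six-membered ring that is kept; the change to compound 3 exchanges that ring for a five-membered one with no hydrogen-bond donor, so no measured step bears on it directly, and both measured numbers are low. Compound 3 is expected to show a step of no more than the scatter, a 1.3-fold lower number from compound 2 to compound 3 (0.12 log units; within the scatter). Compound 3 is estimated at 3 mL.min-1.g-1, within 1 mL.min-1.g-1 to 10 mL.min-1.g-1.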

Compound 3, intrinsic clearance in microsomes: 18 mL.min-1.g-1
The estimate for compound 3 lay 6.0-fold (0.78 log units) below the measured number; the whole stated range lies below it.
By their numbers in this assay, from the lowest: compound 1; then compound 2; then compound 3.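

In this assay, at this aromatic carbon, replacing 4-hydroxy-2-oxopiperidin-1-yl with the five-membered ring with 2 hetero atoms and 0 hydrogen-bond donors gives a 4.5-fold higher number from compound 2 to compound 3 (0.65 log units; beyond the scatter), and the same replacement of 5-hydroxy-2-oxopiperidin-1-yl gives an 18-fold higher number from compound 1 to compound 3 (1.26 log units; beyond the scatter). The position therefore responds to exchange of the whole ring as well as to moving the hydroxyl within it, and compound 3 has the highest number of the three, with its steps to both others beyond the scatter. No measurement available here accounts for this rise.

Ring size, the sulfur-containing group and the absence of the hydroxyl change together in this exchange, so their separate contributions remain unresolved. Going by these compounds, how an amine or a carboxylic acid on this aromatic carbon would read in this assay also remains open.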